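The source may report more compounds than this note shows. Statements on the series, on what has been measured and on what is new or still open speak of the compounds shown alone.

Values in a functional assay on HL-60 cells (Homo sapiens) for inhibition, read by CCK-8 assay, with a stated time of 48 h; a lower number here means a stronger inhibitor, a higher number a weaker inhibitor:
- Compound 1 `O=C(NCCNS(=O)(=O)c1ccc(-c2ccccc2OCc2cccc(O)c2)s1)Nc1cc(Cl)cc(Cl)c1`: 2800 nM
- Compound 2 `O=C(NCCNS(=O)(=O)c1ccc(-c2ccccc2Oc2ccc(O)c(O)c2)s1)Nc1cc(Cl)cc(Cl)c1`: 10400 nM
- Compound 3 `O=C(NCCNS(=O)(=O)c1ccc(-c2ccccc2OCc2ccccc2)s1)Nc1cc(Cl)cc(Cl)c1`: 11700 nM

Compound 1 gives the lowest number of the three, which makes it the strongest inhibitor of this small set. Its gaps to the other two lie beyond the scatter: the measured steps are a 3.7-fold higher number from compound 1 to compound 2 (0.57 log units; beyond the scatter) and a 4.2-fold higher number from compound 1 to compound 3 (0.62 log units; beyond the scatter). The remaining comparison is a 1.1-fold higher number from compound 2 to compound 3 (0.05 log units; within the scatter), so those two compounds cannot be told apart.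

Compound 4 `O=[N+]([O-])c1ccc(NC(=S)NCCNS(=O)(=O)c2ccc(-c3ccccc3OCc3cccc(O)c3)s2)cc1` has not yet been measured. It keeps the core of compound 1 but changes the other end of the molecule: a group of 12 heavy atoms (7 carbon, 2 nitrogen, 2 oxygen, 1 sulfur; one six-membered aromatic ring of carbon only) in place of a group of 11 heavy atoms (7 carbon, 1 nitrogen, 1 oxygen, 2 chlorine; one six-membered aromatic ring of carbon only), on an amine nitrogen. The (3,5-dichlorophenyl)carbamoyl group leaves, and the new group sits on the same amine nitrogen.

Within the data shown here, all three measured compounds carry the (3,5-dichlorophenyl)carbamoyl group, so no measured step tests this change directly. The measured steps serve only as a guide to size. Among the measured compounds shown here, with compound 1 at 2800 nM, the lowest value so far, a modest move to a higher number in this assay is expected, of about the size of a 4.2-fold higher number from compound 1 to compound 3 (0.62 log units; beyond the scatter), though the direction remains uncertain. The expected step is a 1.8-fold higher number from compound 1 to compound 4 (0.25 log units; within the scatter). For compound 4 the estimated value is 5000 nM, with an expected range from 1200 nM to 20000 nM.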

Compound 4, half-maximal inhibitory concentration: 10800 nM
Compound 4: the middle estimate sits 2.2-fold (0.33 log units) below what was measured, within the range that was stated.
By their numbers in this assay, from the lowest: compound 1; then compounds 2, 4 and 3 (each within the scatter of the next).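

Among these compounds, until now, compound 1, compound 2 and compound 3 varied only the far end of the molecule and all kept the (3,5-dichlorophenyl)carbamoyl group, so this result is the first to show that the group on the amine nitrogen also matters in this assay, with a 3.9-fold higher number from compound 1 to compound 4 (0.59 log units; beyond the scatter). The swap replaces the two chlorine atoms and the carbonyl-bearing link with a new group of 12 heavy atoms containing sulfur and two oxygens, so compound 1 remains the strongest inhibitor of the four, and this single step cannot show which of those atomic changes accounts for the difference. No supporting measurement here explains why the swap gives a weaker inhibitor.

The compounds shown leave open whether the link or the ring accounts for the step, a question that a thiocarbonyl link carrying the 3,5-dichlorophenyl ring, or a carbonyl link carrying a nitrophenyl ring, could separate. They also say nothing about how this position responds to quite different ends, such as an unsubstituted phenyl ring, a longer chain or a carboxylic acid.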